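Triazole substituent series: octyl replacing tert-butyl

This account rests on a few compounds, and the source may have more. Where it says the series, first, only, none or still open, it means among the compounds named here.

Measured compounds:
compound 1, `O=c1cc(Cn2cc(CCO)nn2)c2ccc(O)cc2o1`, gives > 100000 nM
compound 2, `CC(O)c1cn(Cc2cc(=O)oc3cc(O)ccc23)nn1`, gives > 100000 nM
compound 3, `CC(C)(C)c1cn(Cc2cc(=O)oc3cc(O)ccc23)nn1`, gives > 100000 nM

All three share one core and differ only in the group on an aromatic carbon of the five-membered aromatic ring with three nitrogens. In a functional assay on CFPAC-1 cells (Homo sapiens) for inhibition, read by MTT assay, with a stated time of 72 h (a higher number here means a weaker inhibitor, a lower number a stronger inhibitor), compound 1 reaches only the assay limit, > 100000 nM. Compound 2 likewise returns a limit and no number, > 100000 nM. Compound 3 also returns a limit, > 100000 nM. The steps among them, a step that the two limits leave unreadable from compound 1 to compound 2, a step that the two limits leave unreadable from compound 1 to compound 3 and a step that the two limits leave unreadable from compound 2 to compound 3, have no readable size because every value sits at the limit of > 100000 nM in this assay, at which 3 of the 3 values shown sit. Compound 3 therefore stands nowhere distinguishable from the other two: a limit, as are the two further values.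

The next change is octyl in place of tert-butyl on an aromatic carbon, giving compound 4, `CCCCCCCCc1cn(Cc2cc(=O)oc3cc(O)ccc23)nn1`. Among the measured compounds shown here, none of the measured steps bears readably on this change, so no direction beyond the scatter can be expected in this assay from the numbers so far. The step expected is a number no higher from compound 3 to compound 4 (the limit leaves the size open), which means no resolvable movement. Compound 4 is thus estimated at 100000 nM, with a range from 20000 nM to 300000 nM, and most likely again a limit rather than a number.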

Compound 4, half-maximal inhibitory concentration: 62700 nM
The estimate for compound 4 lay 1.6-fold (0.20 log units) above the measured number; the measured number falls inside the stated range.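

In this assay compound 4 gives 62700 nM, the only number among the compounds shown, so this position on the five-membered aromatic ring with 3 nitrogen can carry a group that brings the read-out inside the measurable range, though only just. Octyl gives an at least 1.5-fold lower number from compound 3 to compound 4 (0.20 log units; that floor lies within the scatter), and the comparisons with the two hydroxylated chains give an at least 1.5-fold lower number from compound 2 to compound 4 (0.20 log units; that floor lies within the scatter) and an at least 1.5-fold lower number from compound 1 to compound 4 (0.20 log units; that floor lies within the scatter), so none of the three steps is established as a real difference. The steps among compound 1, compound 2 and compound 3 cannot be read, and the new steps are floors rather than sizes, because the other values are all limits: the limit of > 100000 nM in this assay, at which 3 of the 4 values shown sit.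

Still open, on these data alone, is whether a chain between tert-butyl and octyl, such as butyl or hexyl, already gives a number, and whether a longer chain such as dodecyl moves the value clearly beyond the scatter. Also open, as far as these compounds go, is whether an amine or a carboxylic acid at the end of the octyl chain keeps a measurable value.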